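The compounds below may be only part of what the source reports. "The series", "measured", "known", "first", "only" and "open" are said of these compounds alone.

Working notes on the series in a functional assay on MDA-MB-231 cells (Homo sapiens) for cytotoxicity, read by MTT assay, with a stated time of 48 h; on this read-out lower numbers stand for stronger inhibition and higher numbers for weaker inhibition.

Three compounds of the shared core carry a different group on the aromatic nitrogen of the five-membered ring with three nitrogen atoms. Compound 1 `O=C1C[C@H](OCc2cn(-c3ccc(Cl)cc3)nn2)[C@H]2CO[C@@H]1O2` gives 26100 nM. Compound 2 `O=C1C[C@H](OCc2cn(Cc3ccc([N+](=O)[O-])cc3)nn2)[C@H]2CO[C@@H]1O2` gives 25400 nM, and compound 3 `O=C1C[C@H](OCc2cn(Cc3ccc4ccccc4c3)nn2)[C@H]2CO[C@@H]1O2` gives 23700 nM. Compound 1 stands at the highest of the three numbers, but its gap to compound 2 and its gap to compound 3 both lie within the scatter of repeated measurements, so no order can be read among the three. Across a 4-chlorophenyl, a nitro-bearing benzyl and a naphthylmethyl group, this assay shows no movement beyond the scatter.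

Compound 4 `O=C1CCCCC1n1cc(CO[C@H]2CC(=O)[C@@H]3OC[C@H]2O3)nn1` is not yet measured. It differs from compound 1 by one change: 2-oxocyclohexyl in place of 4-chlorophenyl on an aromatic nitrogen. Going by the values given here, with compound 1 at 26100 nM and the other two groups on the same nitrogen giving numbers within the scatter of it, there is no step in the data from which a direction could be taken. The expectation for the step from compound 1 to compound 4 is therefore none beyond the scatter, a 1.1-fold higher number from compound 1 to compound 4 (0.03 log units; within the scatter). For compound 4 the estimate in this assay is 28000 nM, with a range of 13000 nM to 60000 nM.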

Compound 4, half-maximal inhibitory concentration: 36000 nM
Compound 4: the middle estimate sits 1.3-fold (0.11 log units) below what was measured; the measured number falls inside the stated range.
By their numbers in this assay, from the lowest: compounds 3, 2, 1 and 4 (each within the scatter of the next).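

Going by these compounds alone, the step of a 1.4-fold higher number from compound 1 to compound 4 (0.14 log units; within the scatter) in this assay is the first at this nitrogen to replace the aromatic ring with a non-aromatic one, as all three earlier groups carried an aromatic ring of carbon only. It stays within the scatter even though the 2-oxocyclohexyl group brings a hydrogen-bond acceptor and a double bond outside aromatic rings and the chlorine of the 4-chlorophenyl group is lost, so neither an aromatic ring nor a chlorine on this nitrogen is required for a number in this range in this assay. No measurement bears on why this swap leaves the number within the scatter.

This single change alters the ring and adds the carbonyl together, so the compounds shown cannot separate the two, and a plain cyclohexyl group on the same nitrogen would be the direct test. Also open is whether any group here moves the number beyond the scatter, for instance an amine, a carboxylic acid or a longer alkyl chain, since every group shown is built around a six-membered carbon ring.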